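This account rests on a few compounds, and the source may have more. Where it says the series, first, only, none or still open, it means among the compounds named here.

Compound 1: `Cc1cccc(S(=O)(=O)Nc2ccc3oc(-c4ccccc4)nc3c2)c1`. In an assay on cells for inhibition of HSP60/HSP10 (Homo sapiens), with a stated time of 60 min (a higher number here means a weaker inhibitor, a lower number a stronger inhibitor), compound 1 returns only a limit of the assay, > 100000 nM.
Compound 2: `O=S(=O)(Nc1ccc2oc(-c3ccccc3)nc2c1)c1cccs1`. In this assay compound 2 gives 90000 nM.
Compound 3: `COc1cccc(S(=O)(=O)Nc2ccc3oc(-c4ccccc4)nc3c2)c1`. In this assay compound 3 likewise returns only a limit, > 100000 nM.

Compound 3 therefore stands at the edge of what this assay can report; it shares that position with compound 1, as the limit of > 100000 nM in this assay, at which 2 of the 3 values shown sit, shows. Compound 4, `CCc1ccc(S(=O)(=O)Nc2ccc3oc(-c4ccccc4)nc3c2)cc1`, is not yet measured. It differs from compound 3 in one place: 4-ethylphenyl in place of 3-methoxyphenyl on a sulfonyl sulfur.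

Going by the values given here, three measured steps touch the same position on the sulfonyl sulfur. The step that the two limits leave unreadable from compound 1 to compound 3 gives no readable size, the step of an at least 1.1-fold higher number from compound 2 to compound 3 (0.04 log units; that floor lies within the scatter) and the step of an at least 1.1-fold lower number from compound 1 to compound 2 (0.04 log units; that floor lies within the scatter) each have only a floor that lies within the scatter. None of them shows a change beyond the scatter for swapping one aryl or heteroaryl group for another at this position, so a shift of that kind is expected to leave compound 4 in the same region as compound 3.

Compound 4 is therefore expected to sit at or near the limit again, with the expected step of a number no higher from compound 3 to compound 4 (the limit leaves the size open) at or within the scatter. The estimate for compound 4 in this assay is 100000 nM, within 40000 nM to 300000 nM.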

Compound 4, half-maximal inhibitory concentration: > 100000 nM
Compound 4: a limit, no number; the forecaster's own chance of this, stated with the estimate: 65%; the middle value sits exactly at the limit.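

Compound 4 returns only a limit in this assay, so a 4-ethylphenyl group, with carbon alone and no hydrogen-bond acceptor, ends at the same edge as the 3-methylphenyl and 3-methoxyphenyl groups: the limit of > 100000 nM in this assay, at which 3 of the 4 values shown sit. Going by these compounds alone, the one readable new step, an at least 1.1-fold higher number from compound 2 to compound 4 (0.04 log units; that floor lies within the scatter), does not set 4-ethylphenyl apart from thiophen-2-yl. The other two new steps cannot be read, as both ends of each are limits.

On these data alone, whether any group on the sulfonyl sulfur can bring a number clearly lower than that of compound 2 stays open, as only phenyl groups with a small chain or methoxy and a thiophen-2-yl group stand there so far. As far as these compounds go, what an amine or a carboxylic acid on that phenyl ring would do, or a change to the shared core, remains unknown.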